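This account rests on a few compounds, and the source may have more. Where it says the series, first, only, none or still open, it means among the compounds named here.

Measured compounds:
compound 1, `CCCCCCCCc1ccc(OCC(=O)Cn2nnnc2-c2cccc(Cl)c2)cc1`, 360 nM;
compound 2, `CCCCCCCCc1ccc(OCC(=O)Cn2nnnc2-c2cccc(S(=O)(=O)N(C)C)c2)cc1`, 1900 nM;
compound 3, `CCCCCCCCc1ccc(OCC(=O)Cn2nnnc2-c2ccccn2)cc1`, 880 nM.

All three were tested in an assay on microsomes from brain for inhibition of Fatty-acid amide hydrolase 1 (Rattus norvegicus), read by fluorescence and HPLC, with a stated time of 60 min; a higher number here means a weaker inhibitor, a lower number a stronger inhibitor. Compound 3 stands second highest of the three numbers: it sits a 2.2-fold lower number from compound 2 to compound 3 (0.33 log units; beyond the scatter) and a 2.4-fold higher number from compound 1 to compound 3 (0.39 log units; beyond the scatter), so its nearest neighbour is compound 2 and its furthest is compound 1.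

Compound 4, `CCCCCCCCc1ccc(OCC(=O)Cn2nnnc2Cc2ccccc2)cc1`, has not yet been measured. It differs from compound 3 in one place: benzyl in place of pyridin-2-yl on an aromatic carbon. Among the measured compounds shown here, in the earlier steps, exchanging a six-membered aromatic ring that carries a substituent or a ring nitrogen for another moved this assay only modestly, and the carbon-only ring of compound 1 gave the lowest number of the three. For the measured compounds named here, no measured step shows a benzyl group attached through an extra carbon, so the direction of the change for compound 4 is uncertain. A small step is expected, a 1.5-fold lower number from compound 3 to compound 4 (0.17 log units; within the scatter), which falls within the scatter. Compound 4 is therefore estimated at 600 nM, with a likely range of 200 nM to 1800 nM in this assay.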

Compound 4, half-maximal inhibitory concentration: 320 nM
Beside the measured number, compound 4's estimate is 1.9-fold (0.27 log units) above it; low and high end bracket the measured number.
By their numbers in this assay, from the lowest: compounds 4 and 1 (each within the scatter of the next); then compound 3; then compound 2.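

At this carbon of the five-membered aromatic ring with 4 nitrogen, the six-membered ring need not be attached directly: in this assay, benzyl in place of pyridin-2-yl gives a 2.8-fold lower number from compound 3 to compound 4 (0.44 log units; beyond the scatter). Benzyl also compares well with the dimethylsulfamoyl-bearing ring, with a 5.9-fold lower number from compound 2 to compound 4 (0.77 log units; beyond the scatter), while against the 3-chlorophenyl group the change is a 1.1-fold lower number from compound 1 to compound 4 (0.05 log units; within the scatter), so these two groups cannot be told apart in this assay. Nothing available explains these differences.

Compound 4 adds a carbon and removes the ring nitrogen in one change, so the effect of each remains unseparated; a plain phenyl group or a pyridin-2-ylmethyl group would help divide them. Also open, going by these compounds, is how a longer chain, such as 2-phenylethyl, or an amine on the benzyl ring would fare.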